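A few compounds are considered here, and "the series" means these few. Any claim that something is new, unique, unknown or untested is made for them only; others in the source may bear on it.

Of the compounds shown here, three sharing one bridged core have been measured for how strongly they inhibit the growth of rat muscle cells in an ADME assay on L6 cells (Rattus norvegicus) for cytotoxicity; a higher number here means a weaker inhibitor, a lower number a stronger inhibitor. Compound 1, `CCN(CC)CCC(=O)OC1CC2(N3CCCC3)CC(c3ccccc3)C1C(c1ccccc1)C2`, gives 19200 nM in this assay. Compound 2, `CCN(CC)CCC(=O)OC1CC2(N3CCCCC3)CC(c3ccccc3)C1C(c1ccccc1)C2`, carries the change piperidin-1-yl in place of pyrrolidin-1-yl on a saturated ring carbon and gives 22900 nM; the step of a 1.2-fold higher number from compound 1 to compound 2 (0.08 log units; within the scatter) is small. Compound 3, `O=C(CN1CCC(O)CC1)OC1CC2(N3CCCC3)CC(c3ccccc3)C1C(c1ccccc1)C2`, differs from compound 1 by 4-hydroxypiperidin-1-yl in place of (diethylamino)methyl on a saturated chain carbon bound to a carbonyl carbon, and compound 3 gives 93400 nM, so the step of a 4.9-fold higher number from compound 1 to compound 3 (0.69 log units; beyond the scatter) is larger, and compound 3 stands as the weakest inhibitor of the three measured compounds.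

Compound 4, `O=C(CN1CCC(O)CC1)OC1CC2(N3CCCCC3)CC(c3ccccc3)C1C(c1ccccc1)C2`, has not yet been measured. It differs from compound 3 by piperidin-1-yl in place of pyrrolidin-1-yl on a saturated ring carbon, which is the same kind of change as that from compound 1 to compound 2, though not the same: in the earlier pair the ring atom two ring bonds away bears a ((2-(diethylamino)ethyl)carbonyl)oxy group, whereas here it bears a (((4-hydroxypiperidin-1-yl)methyl)carbonyl)oxy group. Because the earlier step of a 1.2-fold higher number from compound 1 to compound 2 (0.08 log units; within the scatter) stayed within the usual scatter, the step from compound 3 to compound 4 is expected to be similarly small, about a 1.1-fold higher number from compound 3 to compound 4 (0.05 log units; within the scatter). On that basis compound 4 is estimated to give 105000 nM in this assay, expected to fall between 55000 nM and 200000 nM.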

Compound 4, half-maximal inhibitory concentration: > 179000 nM
Compound 4: a limit, no number; the forecaster's own chance of this, stated with the estimate: 15%; middle value at least 1.7-fold (0.23 log units) away from the limit.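

In this assay compound 4 gives > 179000 nM, which is a limit of the assay and not a number, so the steps that reach it are floors rather than exact sizes. Putting piperidin-1-yl in place of pyrrolidin-1-yl gives an at least 1.9-fold higher number from compound 3 to compound 4 (0.28 log units; that floor lies within the scatter), so this floor does not show that the ring swap matters on the core carrying the 4-hydroxypiperidin-1-yl side chain, nor does it show that the swap is as small there as on the first core: the same change on two cores in this assay, a 1.2-fold higher number (0.08 log units; within the scatter) from compound 1 to compound 2 and an at least 1.9-fold higher number (0.28 log units; that floor lies within the scatter) from compound 3 to compound 4; the limit leaves it open whether they differ The other change, 4-hydroxypiperidin-1-yl in place of (diethylamino)methyl, gives an at least 7.8-fold higher number from compound 2 to compound 4 (0.89 log units; beyond the scatter), which shows that it raises the number with either ring amine in these two pairs, but not whether it raises it by the same amount: the same change on two cores in this assay, a 4.9-fold higher number (0.69 log units; beyond the scatter) from compound 1 to compound 3 and an at least 7.8-fold higher number (0.89 log units; beyond the scatter) from compound 2 to compound 4; the limit leaves it open whether they differ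

As far as these compounds go, an exact reading for compound 4 would be needed to settle both comparisons, so how well either change carries from one core to the other remains open. The compounds shown also leave open what a morpholin-4-yl group on the same saturated ring carbon, or a longer chain between the carbonyl and the side-chain amine, would do to the number.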